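The compounds below may be only part of what the source reports. "The series", "measured", "known", "first", "only" and "open" are said of these compounds alone.

Among the measured compounds shown here, compound 1 `CC[C@@H](NC(=O)CC(C)C)C(=O)N1CCC(c2ccc(Cl)cc2)CC1` is one of three compounds measured in an assay on THP-1 cells for displacement of a labelled ligand from C-C chemokine receptor type 1 (Homo sapiens); on this read-out lower numbers stand for stronger inhibition and higher numbers for weaker inhibition; compound 1 gives 152 nM. Among the three numbers it stands second highest. Its nearest neighbour is compound 3 `CC[C@@H](NC(=O)CCc1ccccc1)C(=O)N1CCC(c2ccc(Cl)cc2)CC1`, which in this assay gives 85 nM; the step of a 1.8-fold lower number from compound 1 to compound 3 (0.25 log units; within the scatter) replaces the isopropyl of the acyl group with benzyl. For the measured compounds named here, the furthest is compound 2 `CC(C)C(NC(=O)c1ccccc1)C(=O)N1CCN(c2ccc(Cl)cc2)CC1`, which in this assay gives 525 nM, a higher number than compound 1 beyond the scatter; compound 2 differs from compound 1 in several places, so no single step is drawn between them.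

Compound 4 `CC[C@@H](C)[C@@H](NC(=O)CC(C)C)C(=O)N1CCC(c2ccc(Cl)cc2)CC1` differs from compound 1 by ethyl in place of hydrogen on a saturated chain carbon bound to two saturated chain carbons. Going by the values given here, none of the measured steps touches this part of the molecule: the only single-point step, from compound 1 to compound 3, concerns the acyl group and is itself within the scatter. Among the compounds with values here, with no step bearing on the side chain, compound 4 is expected to give a number close to that of compound 1, an expected step of a 1.0-fold lower number from compound 1 to compound 4 (0.01 log units; within the scatter) in this assay, with no direction favoured beyond the scatter. The estimate for compound 4 in this assay is 150 nM, within a range from 55 nM to 420 nM.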

Compound 4, half-maximal inhibitory concentration: 34 nM
For compound 4 the middle estimate is 4.4-fold (0.64 log units) above the measured one; the measured number lies below the stated range.
By their numbers in this assay, from the lowest: compound 4; then compounds 3 and 1 (each within the scatter of the next); then compound 2.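

This is the first single-point change shown that moves the number in this assay beyond the scatter: the change in the acyl group gave only a 1.8-fold lower number from compound 1 to compound 3 (0.25 log units; within the scatter) while ethyl in place of hydrogen on a saturated chain carbon bound to two saturated chain carbons gives a 4.5-fold lower number from compound 1 to compound 4 (0.65 log units; beyond the scatter) and so marks this place as responsive. Read one bond further out, the same difference is ethyl to sec-butyl, so in this single pair the added carbon goes with a lower number. No available evidence accounts for this drop.

The compounds shown leave open whether a longer chain, a hydroxyl or an amine at this place would give a similar number. They also leave open whether the ethyl would combine with the benzyl of compound 3 on the acyl group.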